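Acylguanidine series: piperidin-1-yl replaces ethoxy on the core

This account rests on a few compounds, and the source may have more. Where it says the series, first, only, none or still open, it means among the compounds named here.

Measured so far in a functional assay for inhibition of sodium/hydrogen exchanger (Oryctolagus cuniculus); on this read-out higher numbers stand for weaker inhibition and lower numbers for stronger inhibition:
Compound 1 `Cc1cc(Sc2cccc(Cl)c2)c(S(C)(=O)=O)cc1C(=O)N=C(N)N`: 37 nM
Compound 2 `Cc1cc(Sc2ccncc2)c(S(C)(=O)=O)cc1C(=O)N=C(N)N`: 13 nM
Compound 3 `CCOc1cc(C)c(C(=O)N=C(N)N)cc1S(C)(=O)=O`: 19 nM

Compound 3 sits second highest of the three numbers. Its nearest neighbour is compound 2, a 1.5-fold higher number from compound 2 to compound 3 (0.16 log units; within the scatter); its furthest is compound 1, a 1.9-fold lower number from compound 1 to compound 3 (0.29 log units; within the scatter). Both gaps lie within the scatter, so the three values are not separable by order, and only a 2.8-fold lower number from compound 1 to compound 2 (0.45 log units; beyond the scatter) marks a step beyond the scatter.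

Compound 4 `Cc1cc(N2CCCCC2)c(S(C)(=O)=O)cc1C(=O)N=C(N)N` differs from compound 3 in one place: piperidin-1-yl in place of ethoxy on an aromatic carbon. Among the compounds with values here, no measured step exchanges ethoxy for a ring bearing nitrogen on that aromatic carbon. Within the data shown here, the two steps that touch the same carbon, a 1.9-fold lower number from compound 1 to compound 3 (0.29 log units; within the scatter) and a 1.5-fold higher number from compound 2 to compound 3 (0.16 log units; within the scatter), both stay within the scatter, so the series so far has tolerated quite different groups there without a clear shift. Among the measured compounds shown here, on that basis no step beyond the scatter is expected in either direction, with wide uncertainty since the entering group has no precedent here.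

Compound 4 is therefore estimated at 25 nM, between 8 nM and 80 nM, which would mean an expected 1.3-fold higher number from compound 3 to compound 4 (0.12 log units; within the scatter).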

Compound 4, half-maximal inhibitory concentration: 21 nM
Compound 4: middle estimate off by 1.2-fold (0.08 log units), on the high side; low and high end bracket the measured number.
By their numbers in this assay, from the lowest: compounds 2, 3, 4 and 1 (each within the scatter of the next, the first and the last beyond it).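

At this aromatic carbon, ortho to the methylsulfonyl group, a non-aromatic ring is accepted in this assay: the exchange for ethoxy gives a 1.1-fold higher number from compound 3 to compound 4 (0.04 log units; within the scatter). The exchanges for the two sulfanyl groups read the same way, with a 1.6-fold higher number from compound 2 to compound 4 (0.21 log units; within the scatter) and a 1.8-fold lower number from compound 1 to compound 4 (0.25 log units; within the scatter), so piperidin-1-yl cannot be separated from any of the three groups it replaces. Nothing available accounts for this tolerance.

Within the data shown here, the only step beyond the scatter at this carbon remains the one between compound 1 and compound 2, a 2.8-fold lower number from compound 1 to compound 2 (0.45 log units; beyond the scatter), so the position is not wholly indifferent to what sits there. On these data alone, whether the tolerance extends to a morpholin-4-yl ring, a primary amine or a carboxylic acid on this carbon stays open.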